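This account rests on a few compounds, and the source may have more. Where it says the series, first, only, none or still open, it means among the compounds named here.

Compound 1 `Oc1cc(C(F)(F)F)ccc1-c1nc(-c2ccccc2O)n(-c2ccc(Br)cc2)n1`: 100%
Compound 2 `Oc1cc(C(F)(F)F)ccc1-c1nc(-c2ccccc2O)n(-c2ccccc2C(F)(F)F)n1`: 92.2%
Compound 3 `Oc1cc(C(F)(F)F)ccc1-c1nc(-c2ccccc2O)n(-c2cccc(F)c2)n1`: 98.3%

In a functional assay on PC-12 cells (Rattus norvegicus) for cytotoxicity, read by MTT assay, with stated times of 2 h and 24 h, tested at 10 uM (a higher number here means a stronger effect of the compound at the concentration tested, a lower number a weaker effect), all three measured compounds sit close together. Compound 3 holds the second highest of the three numbers: a number 1.7 percentage points lower from compound 1 to compound 3 (within the scatter) separates it from compound 1, and a number 6.1 percentage points higher from compound 2 to compound 3 (within the scatter) from compound 2, so none of the three can be told apart on this read-out.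

Compound 4 `Oc1cc(C(F)(F)F)ccc1-c1nc(-c2ccccc2O)n(-c2cccc(C(F)(F)F)c2)n1` differs from compound 3 in one place: trifluoromethyl in place of fluoro on an aromatic carbon. Every measured step changes the aryl group on the aromatic nitrogen, and two of them involve the same trifluoromethyl group that enters here: a number 7.8 percentage points lower from compound 1 to compound 2 (within the scatter) brought it in, a number 6.1 percentage points higher from compound 2 to compound 3 (within the scatter) took it out again, and a number 1.7 percentage points lower from compound 1 to compound 3 (within the scatter) swapped one halogenated aryl for another. Within the data shown here, each of these steps stayed within the scatter, so there is no measured step that points to a large move in either direction once a trifluoromethyl replaces a fluoro on the aryl attached to the aromatic nitrogen.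

The expected step is therefore a number 2.3 percentage points lower from compound 3 to compound 4 (within the scatter), that is none beyond the scatter. Compound 4 is estimated at 96% in this assay, with a range from 82% to 100%.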

Compound 4, a percentage reported as activity, at one concentration (the size of the read-out at that concentration, not a potency): 99.9%
Compound 4: middle estimate off by 3.9 percentage points, on the low side, within the range that was stated.
By their numbers in this assay, from the lowest: compounds 2, 3, 4 and 1 (each within the scatter of the next).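

In this assay, trifluoromethyl in place of fluoro on an aromatic carbon, meta to a large group, gives a number 1.6 percentage points higher from compound 3 to compound 4 (within the scatter), so a group of 4 heavy atoms cannot be told apart from one of 1 heavy atom at this place. The comparisons on the aromatic nitrogen read the same way: 3-(trifluoromethyl)phenyl in place of 2-(trifluoromethyl)phenyl gives a number 7.7 percentage points higher from compound 2 to compound 4 (within the scatter), and 3-(trifluoromethyl)phenyl in place of 4-bromophenyl gives a number 0.1 percentage points lower from compound 1 to compound 4 (within the scatter), so neither moving the trifluoromethyl group on that aryl nor exchanging this aryl for the bromine-bearing one separates the compounds on this read-out. Nothing available on these compounds speaks to what lies behind these numbers.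

All four compounds carry a halogen or trifluoromethyl group on the aryl attached to the aromatic nitrogen, so the compounds shown leave open whether an amine, a carboxylic acid or a longer chain at this place would stand apart from them in this assay. They also leave open how the shared core would read with either of its hydroxyl groups replaced by a methoxy group.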